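From 3-chlorophenyl to 2-bromophenyl: a halogen swap

The source may hold more compounds than are shown below. What is called first, only, known or untested is meant among the compounds shown, and "the series" means these compounds.

Measured in a functional assay; on this read-out lower numbers stand for stronger inhibition and higher numbers for weaker inhibition:
Compound 1 `CC(C)=CCOc1cc(O)c2c(c1)OC(c1ccccc1)CC2=O`: 7320 nM
Compound 2 `CC(C)=CCOc1cc(O)c2c(c1)OC(c1ccccc1F)CC2=O`: 5300 nM
Compound 3 `CC(C)=CCOc1cc(O)c2c(c1)OC(c1cccc(Cl)c1)CC2=O`: 6060 nM

Compound 3, at 6060 nM, lies within the scatter of both other compounds. Compound 4 `CC(C)=CCOc1cc(O)c2c(c1)OC(c1ccccc1Br)CC2=O` carries 2-bromophenyl in place of 3-chlorophenyl on a saturated ring carbon. The closest evidence comes from the halogen changes already measured: fluoro in place of hydrogen gave a 1.4-fold lower number from compound 1 to compound 2 (0.14 log units; within the scatter), chloro in place of hydrogen gave a 1.2-fold lower number from compound 1 to compound 3 (0.08 log units; within the scatter), and exchanging the two halogenated phenyl groups gave a 1.1-fold higher number from compound 2 to compound 3 (0.06 log units; within the scatter). Within the data shown here, all three stay within the scatter, so no step beyond the scatter is expected in this assay, in either direction, although no bromo compound has been measured yet. The estimated change is a 1.1-fold lower number from compound 3 to compound 4 (0.04 log units; within the scatter). Compound 4 is estimated at 5500 nM, with a likely range of 3000 nM to 10000 nM.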

Compound 4, half-maximal inhibitory concentration: 3820 nM
Beside the measured number, compound 4's estimate is 1.4-fold (0.16 log units) above it; the measured number falls inside the stated range.
By their numbers in this assay, from the lowest: compounds 4, 2, 3 and 1 (each within the scatter of the next).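

In this assay, bromo on the phenyl group at this saturated ring carbon stays within the scatter of all three earlier compounds: the swap from 3-chlorophenyl to 2-bromophenyl gives a 1.6-fold lower number from compound 3 to compound 4 (0.20 log units; within the scatter), bromo for fluoro gives a 1.4-fold lower number from compound 2 to compound 4 (0.14 log units; within the scatter), and bromo for hydrogen gives a 1.9-fold lower number from compound 1 to compound 4 (0.28 log units; within the scatter). Fluoro, chloro and bromo have now all been placed on this phenyl group with no step beyond the scatter. No outside measurement helps to explain these close numbers.

Still open, going by these compounds, is whether a non-halogen group on this phenyl ring, such as an amine or a carboxylic acid, would produce a step beyond the scatter.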